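Dichlorophenyl Added to the Weaker Member of a Pair

A few compounds are considered here, and "the series" means these few. Any claim that something is new, unique, unknown or untested is made for them only; others in the source may bear on it.

Of the compounds shown here, two built on a shared core have been tested in a functional assay on BCG823 cells (Homo sapiens) for inhibition, read by MTT assay, with a stated time of 72 h; a higher number here means a weaker inhibitor, a lower number a stronger inhibitor. Compound 1 `CN(C(=O)NC(=O)c1ccc(Cl)c(Cl)c1)c1nc(C(F)(F)F)c(C(=O)N/N=C/c2ccc([N+](=O)[O-])cc2)s1` gives 2.13 ug/mL. Compound 2 `CN(C(=O)NC(=O)c1ccccc1)c1nc(C(F)(F)F)c(C(=O)N/N=C/c2cccc([N+](=O)[O-])c2)s1` gives 13.6 ug/mL, the higher of the two numbers; its nearest neighbour, compound 1, sits at a lower number, and that gap lies beyond the scatter. Within the data shown here, the two compounds differ in two places at once, so no single step between them can be read from these values.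

Compound 3 `CN(C(=O)NC(=O)c1ccc(Cl)c(Cl)c1)c1nc(C(F)(F)F)c(C(=O)N/N=C/c2cccc([N+](=O)[O-])c2)s1` has not yet been measured. It changes compound 2 in one place: 3,4-dichlorophenyl in place of phenyl on a carbonyl carbon. The difference that remains between compound 3 and compound 1 lies elsewhere in the molecule.

A downward step of moderate size is expected here, because compound 1, which carries the same 3,4-dichlorophenyl group, gives 2.13 ug/mL, and part of its gap to compound 2 may belong to this change rather than to the other difference. The expected step is a 2.5-fold lower number from compound 2 to compound 3 (0.39 log units; beyond the scatter). Compound 3 is estimated at 5.5 ug/mL, with a range from 2 ug/mL to 14 ug/mL.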

Compound 3, half-maximal inhibitory concentration: 4.87 ug/mL
Compound 3: middle estimate off by 1.1-fold (0.05 log units), on the high side; measured number inside the range.
By their numbers in this assay, from the lowest: compound 1; then compound 3; then compound 2.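

In this assay the exchange of phenyl for 3,4-dichlorophenyl on the carbonyl carbon now has a size of its own, read with the 3-nitrophenyl group held fixed: a 2.8-fold lower number from compound 2 to compound 3 (0.45 log units; beyond the scatter) for this single change. Compound 3 also separates out the other difference, 3-nitrophenyl in place of 4-nitrophenyl on the carbon with a double bond to nitrogen, as a 2.3-fold higher number from compound 1 to compound 3 (0.36 log units; beyond the scatter) with the 3,4-dichlorophenyl group held fixed, so each change taken alone moves the number by a modest step beyond the scatter. Nothing available gives a reason for either step.

The compounds shown leave open whether the dichlorophenyl step keeps its size when 4-nitrophenyl stands on the carbon with a double bond to nitrogen, since each step has been read against a single partner group. They also leave open how a 4-chlorophenyl, a 4-methoxyphenyl or a pyridine ring would behave on the carbonyl carbon, and how an aminophenyl group would compare with the two nitrophenyl groups.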